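This account rests on a few compounds, and the source may have more. Where it says the series, first, only, none or still open, it means among the compounds named here.

Compound 1 `Nc1scc(CN2CCN(c3cccc(C(F)(F)F)c3)CC2)c1C(=O)c1ccc(Cl)cc1` is the reference point of this small set. In an assay on CHO cells for displacement of a labelled ligand from adenosine receptor A1 (Homo sapiens), read by scintillation counting, with a stated time of 120 min, tested at 10 uM (on this read-out lower numbers stand for less inhibition and higher numbers for more inhibition at the one concentration tested (going by the name of the read-out)), compound 1 gives 0%, level with compound 3 at the digits shown and together with it the lowest of the three numbers, although every gap among them lies within the scatter. Compound 2 `Nc1scc(CN2CCN(c3ccncc3)CC2)c1C(=O)c1ccc(Cl)cc1` carries a pyridin-4-yl on the amine nitrogen in the ring; in this assay compound 2 gives 1%, a step of a number 1 percentage points higher from compound 1 to compound 2 (within the scatter). Compound 3 `Nc1scc(CN2CCN(c3cccc(F)c3F)CC2)c1C(=O)c1ccc(Cl)cc1` carries a 2,3-difluorophenyl at the same place; in this assay compound 3 gives 0%, with no change at the digits printed from compound 1 to compound 3 (within the scatter) and a number 1 percentage points lower from compound 2 to compound 3 (within the scatter). Compound 4 `Nc1scc(CN2CCN(c3ccc(F)c(Cl)c3)CC2)c1C(=O)c1ccc(Cl)cc1` still awaits measurement. It differs from compound 1 in one place: 3-chloro-4-fluorophenyl in place of 3-(trifluoromethyl)phenyl on an amine nitrogen in a ring. All three measured steps exchange the aryl on the same ring nitrogen, and none of them moved the read-out beyond the scatter, so no step beyond the scatter is expected here either: a number 1 percentage points higher from compound 1 to compound 4 (within the scatter). Compound 4 is accordingly expected to give 1%, somewhere between -6% and 12%.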

Compound 4, a percentage reported as inhibition, at one concentration (the size of the read-out at that concentration, not a potency): 0%
Beside the measured number, compound 4's estimate is 1 percentage points above it; the range from low to high includes it.
By their numbers in this assay, from the lowest: compounds 1, 3, 4 and 2 (each within the scatter of the next).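

In this assay the exchange to 3-chloro-4-fluorophenyl on an amine nitrogen in a ring gives no change at the digits printed from compound 1 to compound 4 (within the scatter) and no change at the digits printed from compound 3 to compound 4 (within the scatter) and a number 1 percentage points lower from compound 2 to compound 4 (within the scatter) as its three readings. This adds an aryl carrying both chlorine and fluorine to the earlier 3-(trifluoromethyl)phenyl, pyridin-4-yl and 2,3-difluorophenyl, and the four groups still cannot be told apart at this position on this read-out. No supporting data bear on why the aryl exchanges leave the number unmoved.

Still open, as far as these compounds go, is whether anything other than an aryl on this nitrogen, such as a cyclohexyl, an acetyl or a longer alkyl chain, would separate from these compounds. Equally open, from the compounds shown here alone, is whether a carboxylic acid or an amine on the phenyl would do so.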